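The source may hold more compounds than are shown below. What is called first, only, known or untested is meant among the compounds shown, and "the series" means these compounds.

Three compounds that share one core have been run in an ADME assay on RAW264.7 cells (Mus musculus) for cytotoxicity, read by MTT assay, with a stated time of 72 h; on this read-out lower numbers stand for stronger inhibition and higher numbers for weaker inhibition. Compound 1 `CC(=O)N1CCN(CC(=O)N2CCN(c3cc4c(cc3F)c(=O)c(C(=O)O)cn4C3CC3)CC2)CC1` gives 154000 nM. Compound 2 `O=C(O)c1cn(C2CC2)c2cc(N3CCN(C(=O)CN4CCN(c5ccccc5Cl)CC4)CC3)c(F)cc2c1=O`, with 2-chlorophenyl in place of acetyl on an amine nitrogen in a ring, gives 167000 nM. Compound 3 `CC(c1ccccc1)N1CCN(CC(=O)N2CCN(c3cc4c(cc3F)c(=O)c(C(=O)O)cn4C3CC3)CC2)CC1` gives 148000 nM. Compound 3 stands together with the other two: its gaps to compound 1 and to compound 2 both fall within the scatter, so none of the three can be set apart.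

Compound 4 `O=C(O)c1cn(C2CC2)c2cc(N3CCN(C(=O)CN4CCN(c5ncccn5)CC4)CC3)c(F)cc2c1=O` awaits measurement. It differs from compound 3 in one place: pyrimidin-2-yl in place of 1-phenylethyl on an amine nitrogen in a ring. Going by the values given here, two measured steps touch that same position. a 1.0-fold lower number from compound 1 to compound 3 (0.02 log units; within the scatter), and a 1.1-fold lower number from compound 2 to compound 3 (0.05 log units; within the scatter). Acetyl, 2-chlorophenyl and 1-phenylethyl on that ring nitrogen thus give the same read-out within the scatter, and nothing in these data marks the pyrimidin-2-yl as an exception. The expected step is therefore a 1.0-fold higher number from compound 3 to compound 4 (0.02 log units; within the scatter), nothing beyond the scatter. Compound 4 is estimated at 155000 nM, with a range from 95000 nM to 250000 nM.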

Compound 4, half-maximal inhibitory concentration: 227000 nM
Estimate against measurement, compound 4: 1.5-fold (0.17 log units) below; low and high end bracket the measured number.
By their numbers in this assay, from the lowest: compounds 3, 1, 2 and 4 (each within the scatter of the next).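

In this assay, going by these compounds alone, the pyrimidin-2-yl of compound 4 puts a six-membered aromatic ring with 2 hetero atoms on the amine nitrogen in a ring, where the aromatic rings of the earlier compounds, in 2-chlorophenyl and 1-phenylethyl, held carbon only. This change gives the widest steps yet seen at this position, a 1.5-fold higher number from compound 3 to compound 4 (0.19 log units; within the scatter), a 1.4-fold higher number from compound 2 to compound 4 (0.13 log units; within the scatter) and a 1.5-fold higher number from compound 1 to compound 4 (0.17 log units; within the scatter), yet all of them stay within the scatter, so the flat picture now extends from acetyl and carbon-only aromatic groups to an aromatic ring carrying hetero atoms, and compound 4 cannot be set apart from the other three. No measurement at hand speaks to what lies behind these readings, so the small shift carries no explanation here.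

Going by these compounds, it remains open whether a group of another kind on this ring nitrogen, such as a carboxylic acid, a primary amine on a longer chain or a plain hydrogen, would carry the number beyond the scatter. The compounds shown also vary only this one position, so they say nothing about how the read-out responds to a change elsewhere on the shared core, such as replacing the cyclopropyl or the carboxylic acid.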